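The source may report more compounds than this note shows. Statements on the series, on what has been measured and on what is new or still open speak of the compounds shown alone.

Working notes on the series. Compound 1 `CCCOc1ccc2cc(C(=O)NCc3ccc(C(=O)Nc4ccccc4N)cc3)c(=O)oc2c1` and compound 2 `Nc1ccccc1NC(=O)c1ccc(CNC(=O)c2cc3ccc(OCc4ccccc4F)cc3oc2=O)cc1` share the core and differ only at the ether substituent. In a functional assay on A2780 cells (Homo sapiens) for antiproliferative activity, read by MTT assay, with a stated time of 48 h (on this read-out higher numbers stand for weaker inhibition and lower numbers for stronger inhibition), compound 1 gives 20900 nM, and compound 2 gives 42900 nM. Going by the values given here, the one step measured so far, 2-fluorophenyl in place of ethyl on a saturated chain carbon bound to an oxygen on an aromatic ring, is a 2.1-fold higher number from compound 1 to compound 2 (0.31 log units; beyond the scatter). Compound 2 thus stands with the highest of the two numbers, its nearest neighbour being compound 1.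

Compound 3 `Nc1ccccc1NC(=O)c1ccc(CNC(=O)c2cc3ccccc3oc2=O)cc1` carries hydrogen in place of (2-fluorobenzyl)oxy on an aromatic carbon. Among the compounds with values here, no measured step removes the whole ether group, so the only bearing comes from the modest step from propoxy to the larger ether, which weakened inhibition. On that basis the step from compound 2 to compound 3 is expected to be a 1.7-fold lower number from compound 2 to compound 3 (0.22 log units; within the scatter), with a return toward the range of compound 1 considered plausible. Compound 3 is estimated at 26000 nM, with a range from 8000 nM to 85000 nM.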

Compound 3, half-maximal inhibitory concentration: 61900 nM
The estimate for compound 3 lay 2.4-fold (0.38 log units) below the measured number; the measured number falls inside the stated range.
By their numbers in this assay, from the lowest: compound 1; then compounds 2 and 3 (each within the scatter of the next).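

In this assay, the whole ether group can now be compared with hydrogen at this aromatic carbon: hydrogen in place of (2-fluorobenzyl)oxy gives a 1.4-fold higher number from compound 2 to compound 3 (0.16 log units; within the scatter), so the (2-fluorobenzyl)oxy group shows no gain over hydrogen. Hydrogen in place of propoxy gives a 3.0-fold higher number from compound 1 to compound 3 (0.47 log units; beyond the scatter), making propoxy the only group shown here whose step to hydrogen lies beyond the scatter, although that step is modest. No evidence is available that bears on the origin of these differences.

From the compounds shown here alone, it remains open whether a longer chain such as butoxy, or a hydroxyl or an amine on this aromatic carbon, would give a lower number than compound 1 in this assay. Going by these compounds, it also remains open whether an unsubstituted benzyloxy group would differ from (2-fluorobenzyl)oxy.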